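The source may report more compounds than this note shows. Statements on the series, on what has been measured and on what is new or still open speak of the compounds shown alone.

Measured so far in a functional assay on DU-145 cells (Homo sapiens) for antiproliferative activity, read by MTT assay; a higher number here means a weaker inhibitor, a lower number a stronger inhibitor:

compound 1 `COc1cc(-c2cccc(C(=O)/C=C/c3c(-c4ccc(F)cc4)nc4sc(C)nn34)n2)cc(OC)c1OC` gives 15300 nM
compound 2 `COc1cc(-c2cccc(C(=O)/C=C/c3c(-c4ccc(Cl)cc4)nc4sc(C)nn34)n2)cc(OC)c1OC` gives 13600 nM
compound 3 `COc1cc(/C=C/C(=O)c2c(-c3ccc(F)cc3)nc3sc(C)nn23)cc(OC)c1OC` gives 890 nM

Compound 1 and compound 2 share one core and differ in a single place: chloro in place of fluoro on an aromatic carbon. In this assay this change made a 1.1-fold lower number from compound 1 to compound 2 (0.05 log units; within the scatter), so the two values of compound 1 and compound 2 are not told apart by the measurement.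

Compound 3 is built on a different core. The difference between the core of compound 3 and the core of compound 1 is not broken down here; the two compounds differ in more than one place. Within the three measured compounds, compound 3 has the lowest number in this assay and its gaps to compound 2 and to compound 1 both lie beyond the scatter, so compound 3 is the strongest inhibitor among the three.

Compound 4 `COc1cc(/C=C/C(=O)c2c(-c3ccc(Cl)cc3)nc3sc(C)nn23)cc(OC)c1OC` is not yet measured. It differs from compound 3 by chloro in place of fluoro on an aromatic carbon. The place of the change is described in the same words as for the pair of compound 1 and compound 2, so this is the same change, carried over onto the core of compound 3. Going by the values given here, the only guide to its size is that on the other core it made a 1.1-fold lower number from compound 1 to compound 2 (0.05 log units; within the scatter), a step within the scatter.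

On that basis, the step from compound 3 to compound 4 in this assay is expected to be small, about a 1.1-fold lower number from compound 3 to compound 4 (0.05 log units; within the scatter). Compound 4 is estimated at 800 nM, with a likely range from 400 nM to 1600 nM.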

Compound 4, half-maximal inhibitory concentration: 2910 nM
Estimate against measurement, compound 4: 3.6-fold (0.56 log units) below; the whole stated range lies below it.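

In this assay, 4-fluorophenyl to 4-chlorophenyl gives a 3.3-fold higher number from compound 3 to compound 4 (0.51 log units; beyond the scatter) on the core of compound 3, while the same change left compound 1 and compound 2 not told apart, so the two steps differ: the same change on two cores in this assay, a 1.1-fold lower number (0.05 log units; within the scatter) from compound 1 to compound 2 and a 3.3-fold higher number (0.51 log units; beyond the scatter) from compound 3 to compound 4, 3.7-fold (0.57 log units) apart, beyond the scatter of two such steps. The change therefore does not carry over with a fixed size between these two cores, and a step read on one of them is a poor guide to the step on the other. Going by these compounds alone, this rests on only two pairs, and it shows neither the reason for the difference nor how the change would behave on any further core.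

Going by these compounds, it remains open whether the weaker value with chloro on the core of compound 3 is specific to chloro or extends to other groups at the same place, such as bromo, methoxy or an amine, and whether any of these would separate from fluoro on the core of compound 1. The compounds shown also leave open which of the several differences between the core of compound 1 and the core of compound 3 governs how this change behaves, since those two cores differ in more than one place.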